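The source may hold more compounds than are shown below. What is called first, only, known or untested is meant among the compounds shown, and "the series" means these compounds.

Of the compounds shown here, three have been measured in an assay on isolated protein for inhibition of Amine oxidase [flavin-containing] B (Homo sapiens), read by fluorescence and Amplex Red, with stated times of 15 min and 20 min; a higher number here means a weaker inhibitor, a lower number a stronger inhibitor. Compound 1 `CC(C)=CCc1c(O)cc(/C=C/c2ccc3c(c2)[C@H](c2cc(O)c(CC=C(C)C)c(O)c2)[C@@H](c2ccc(O)cc2)O3)cc1O` gives 920 nM in this assay. Compound 2 `CC(C)=CCc1c(O)cc(/C=C/c2ccc(O)cc2)cc1O` gives 3620 nM in this assay. Compound 3 `CC(C)=CCc1c(O)cc([C@@H](Oc2ccc(/C=C/c3cc(O)c4c(c3)OC(C)(C)CC4)cc2)[C@@H](C)c2ccc(O)cc2)cc1O` gives 9230 nM in this assay, the highest number of the three. Its gap to compound 2 and its gap to compound 1 both lie beyond the usual scatter of repeated measurements, so compound 3 is the weakest inhibitor among the measured compounds.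

Compound 4 `CO[C@@H](c1ccc(O)cc1)[C@H](Oc1ccc(/C=C/c2cc(O)c3c(c2)OC(C)(C)CC3)cc1)c1cc(O)c(CC=C(C)C)c(O)c1` has not yet been measured. It differs from compound 3 in a single place: methoxy in place of methyl on a saturated chain carbon bound to an aromatic carbon and a saturated chain carbon. Everything else in the two structures is the same.

For the measured compounds named here, no pair of measured compounds differs by this change alone, so the numbers at hand say nothing direct about what it does. With only the structural change to go on, the expected step of a 1.0-fold lower number from compound 3 to compound 4 (0.01 log units; within the scatter) is small, without a clear direction, and most likely within the scatter. Compound 3 itself sits at the weak end of the measured range, and a swap of one small group on a saturated chain carbon is not expected to move it far.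

Compound 4 is therefore estimated at 9000 nM in this assay, with a range from 3000 nM to 27000 nM.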

Compound 4, half-maximal inhibitory concentration: 1900 nM
Beside the measured number, compound 4's estimate is 4.7-fold (0.68 log units) above it; measured number outside the range, below it.
By their numbers in this assay, from the lowest: compound 1; then compounds 4 and 2 (each within the scatter of the next); then compound 3.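

In this assay, putting methoxy in place of methyl on a saturated chain carbon bound to an aromatic carbon and a saturated chain carbon gives a 4.9-fold lower number from compound 3 to compound 4 (0.69 log units; beyond the scatter) and so a modest gain in inhibition. For the compounds shown here, the earlier compounds included no pair differing in one place, so this is the first direct sign that the number responds to what sits on this carbon, and here the change that enters one oxygen atom and one hydrogen-bond acceptor goes with stronger inhibition. No measurement at hand explains the step.

The compounds shown leave open whether the oxygen atom matters or whether any group larger than methyl on this carbon would do the same. An ethyl group, which has the same count of heavy atoms as methoxy but no oxygen, would address that question, and a hydroxyl group or an amine on the same carbon would show how far the step depends on the methyl cap of the methoxy or on the kind of atom attached.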